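Lengthening the Amide Chain from Butyl to Hexyl

The source may hold more compounds than are shown below. What is called first, only, known or untested is meant among the compounds shown, and "the series" means these compounds.

Three amides of one core have been tested in a functional assay on the whole organism (strain Wistar) for inhibition, with Rattus norvegicus as the target, read by paw edema, with stated times of 60 min and 24 h, at a dose of 100 mg/kg by the oral route; a lower number here means less inhibition, a higher number more inhibition at the dose given (going by the name of the read-out). Compound 1 `COc1cc2c(cc1OC)C(CC(N)=O)CC2` gives 26.7%, compound 2 `CNC(=O)CC1CCc2cc(OC)c(OC)cc21` gives 33.3%, and compound 3 `CCCCNC(=O)CC1CCc2cc(OC)c(OC)cc21` gives 36.7%. Compound 3 carries the highest of the three numbers, but the step of a number 10 percentage points higher from compound 1 to compound 3 (within the scatter) and the step of a number 3.4 percentage points higher from compound 2 to compound 3 (within the scatter) both lie within the scatter, so the three compounds cannot be told apart with confidence.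

Compound 4 `CCCCCCNC(=O)CC1CCc2cc(OC)c(OC)cc21` has not been measured. It differs from compound 3 by ethyl in place of hydrogen on a saturated chain carbon, four bonds along the chain from an amide-type nitrogen. The two earlier steps that grow the chain on the amide nitrogen bear most closely on this change: a number 6.6 percentage points higher from compound 1 to compound 2 (within the scatter) and a number 3.4 percentage points higher from compound 2 to compound 3 (within the scatter). Each adds carbon to the same chain, and neither moved the read-out beyond the scatter. There is no measurement of a chain longer than butyl, so the data give no ground for a larger effect either way.

Compound 4 is therefore expected to give a number close to that of compound 3, with the step of a number 1.3 percentage points higher from compound 3 to compound 4 (within the scatter) expected to stay within the scatter. The estimate for compound 4 in this assay is 38%, with a range from 25% to 51%.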

Compound 4, a percentage reported as inhibition, in the whole organism at one dose (the size of the read-out at that dose, not a potency): 45.5%
Compound 4: middle estimate off by 7.5 percentage points, on the low side, and the stated range covers the measured number.
By their numbers in this assay, from the lowest: compounds 1, 2, 3 and 4 (each within the scatter of the next, the first and the last beyond it).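

In this assay the ethyl extension of the butyl chain gives a number 8.8 percentage points higher from compound 3 to compound 4 (within the scatter) and so cannot, taken alone, be separated from compound 3. Measured against the shorter amides, however, the hexyl chain gives the only steps among these compounds that clear the scatter, with a number 12.2 percentage points higher from compound 2 to compound 4 (beyond the scatter) and a number 18.8 percentage points higher from compound 1 to compound 4 (beyond the scatter) both modest in size, whereas the butyl chain of compound 3 stays within the scatter of both compound 1 and compound 2. The chain on the amide nitrogen can therefore change the read-out at this dose, though only over the full distance from the shorter amides, and nothing given here accounts for that change.

The compounds shown leave open whether an octyl chain would raise the read-out further or bring it back down, and what a branched chain, a terminal amine or a terminal carboxylic acid on the hexyl chain would do. Going by these compounds, the read-out comes from a single oral dose, and how these amides compare in potency also remains open.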